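Swapping a Bromine Arm for a Fluorinated One

A few compounds are considered here, and "the series" means these few. Any claim that something is new, unique, unknown or untested is made for them only; others in the source may bear on it.

Compound 2 `CCS(=O)(=O)c1ccc(CNC(=O)c2ccc3c(c2)cc(Cc2ccccc2Br)n3C(C)C)cc1` is one of two compounds with a number in hand. In an ADME assay on microsomes from liver (Homo sapiens) for metabolic stability (on this read-out higher numbers stand for a longer-lived compound and lower numbers for a shorter-lived compound), compound 2 gives 0.25 h, the lowest of the two numbers. Its nearest neighbour is compound 1 `CCS(=O)(=O)c1ccc(CNC(=O)c2ccc3c(c2)cc(Cc2ccc(Cl)cc2C(F)(F)F)n3C(C)C)cc1`, which in this assay gives 3.03 h, and the step of a 12-fold lower number from compound 1 to compound 2 (1.08 log units; beyond the scatter) is large. Compound 3 `CCS(=O)(=O)c1ccc(CNC(=O)c2ccc3c(c2)cc(Cc2ccc(F)cc2C(F)(F)F)n3C(C)C)cc1` has not yet been measured. Its difference from compound 2 is 4-fluoro-2-(trifluoromethyl)phenyl in place of 2-bromophenyl on a saturated chain carbon bound to an aromatic carbon. The group entering compound 3 shares the trifluoromethyl group of compound 1, with fluorine standing where compound 1 has chlorine, so the step from compound 1 to compound 2 is the one that bears on this change, read in reverse. Because the step of a 12-fold lower number from compound 1 to compound 2 (1.08 log units; beyond the scatter) was large, the expected step in this assay is an 8.0-fold higher number from compound 2 to compound 3 (0.90 log units; beyond the scatter). For compound 3 the estimate in this assay is 2 h, with a range from 0.7 h to 5 h.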

Compound 3, half-life: 1.2 h
Compound 3: middle estimate off by 1.7-fold (0.22 log units), on the high side, within the range that was stated.
By their numbers in this assay, from the lowest: compound 2; then compound 3; then compound 1.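

In this assay the arm carrying trifluoromethyl again reads above the 2-bromophenyl arm, now with fluoro as its second halogen, giving a 4.8-fold higher number from compound 2 to compound 3 (0.68 log units; beyond the scatter) for this change. The arm's identity is not settled by the trifluoromethyl group alone, since fluoro in place of chloro on an aromatic carbon gives a 2.5-fold lower number from compound 1 to compound 3 (0.40 log units; beyond the scatter) and so this single-atom swap also moves the half-life beyond the scatter. No measurement at hand accounts for either step.

Compound 2 and compound 3 differ in both the trifluoromethyl and the fluoro group at once, so the share of each in their step stays unresolved. Also open, as far as these compounds go, is how the half-life would read with a nitrile or a methoxy group in place of the fluoro, or with a plain 2-(trifluoromethyl)phenyl arm.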